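Methoxy on the anilide ring of the cinnamyl piperidine carboxamide

The source may report more compounds than this note shows. Statements on the series, on what has been measured and on what is new or still open speak of the compounds shown alone.

Going by the values given here, compound 1, `O=C(Nc1ccccc1)C1CCN(C/C=C/c2ccccc2)CC1`, is the weaker of the two compounds measured so far in a functional assay on MCF7 cells (Homo sapiens) for inhibition, read by MTT assay, with a stated time of 72 h (a higher number here means a weaker inhibitor, a lower number a stronger inhibitor), where compound 1 gives 60200 nM. Compound 2, `CCCc1ccc(NC(=O)C2CCN(C/C=C/c3ccccc3)CC2)cc1`, differs only by propyl in place of hydrogen on an aromatic carbon, and in this assay compound 2 gives 9030 nM; the step of a 6.7-fold lower number from compound 1 to compound 2 (0.82 log units; beyond the scatter) shows that a substituent on this ring can lower the number. Compound 3, `COc1ccccc1NC(=O)C1CCN(C/C=C/c2ccccc2)CC1`, is the untested compound; it differs from compound 1 by methoxy in place of hydrogen on an aromatic carbon. Among the compounds with values here, no measured step involves methoxy, and the only guide is the propyl step from compound 1 to compound 2, which was modest. A somewhat smaller gain is therefore expected, with wide uncertainty: the step of a 2.0-fold lower number from compound 1 to compound 3 (0.30 log units; within the scatter) is the estimate. For compound 3 in this assay the expected value is 30000 nM, within a range of 8000 nM to 120000 nM.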

Compound 3, half-maximal inhibitory concentration: > 100000 nM
Compound 3 gave a limit, no number; the forecaster's own chance of this, stated with the estimate: 10%; at least 3.3-fold (0.52 log units) between middle value and limit.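

In this assay compound 3 gives a limit and not a number: the limit of > 100000 nM in this assay, at which 1 of the 3 values shown sits. The step of an at least 1.6-fold higher number from compound 1 to compound 3 (0.22 log units; that floor lies within the scatter) shows that a substituent on this ring does not always lower the number: methoxy, ortho to a large group, gave no lowering of the kind seen with propyl, although this floor alone does not establish a rise beyond the scatter. The step of an at least 11-fold higher number from compound 2 to compound 3 (1.04 log units; beyond the scatter), with 2-methoxyphenyl in place of 4-propylphenyl on the amide-type nitrogen, sets these two substituted compounds clearly apart.

That step changes both the group and its place on the ring, so the compounds shown do not tell which of the two matters. Also open, from the compounds shown here alone, is how methoxy elsewhere on this ring, propyl in the place methoxy holds here, or an amine or a carboxylic acid on this ring would read.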